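Swapping a Six-Membered Ring for a Five-Membered One

A few compounds are considered here, and "the series" means these few. Any claim that something is new, unique, unknown or untested is made for them only; others in the source may bear on it.

Of the compounds shown here, three sharing one core have been tested in a functional assay on A549 cells (Homo sapiens) for antiproliferative activity, read by MTT assay, with a stated time of 72 h; a lower number here means a stronger inhibitor, a higher number a weaker inhibitor. Compound 1 `COc1cc(F)c(NC(=O)c2ccncc2)cc1Nc1nccc(-c2cn(C)c3ccccc23)n1` gives 4200 nM. Compound 2 `COc1cc(F)c(NC(=O)c2ccnc(O)c2)cc1Nc1nccc(-c2cn(C)c3ccccc23)n1`, which carries an added hydroxy group, gives 11700 nM, and compound 3 `COc1cc(F)c(NC(=O)c2cnccn2)cc1Nc1nccc(-c2cn(C)c3ccccc23)n1` gives 2490 nM. Compound 3 thus shows the lowest of the three numbers, though its separation from compound 1 is small: a 1.7-fold lower number from compound 1 to compound 3 (0.23 log units; within the scatter). Against compound 2 the gap is clearer: a 4.7-fold lower number from compound 2 to compound 3 (0.67 log units; beyond the scatter). Compound 4 `COc1cc(F)c(NC(=O)c2nccn2C)cc1Nc1nccc(-c2cn(C)c3ccccc23)n1` has not yet been measured; it differs from compound 3 in one place: 1-methyl-1H-imidazol-2-yl in place of pyrazin-2-yl on a carbonyl carbon.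

For the measured compounds named here, the only measured steps that alter the ring attached to the carbonyl carbon are the two that lead to compound 3, and each of them exchanges one six-membered aromatic ring for another, so the move to a five-membered ring is untested in this set. The expectation for compound 4 is a step of roughly this size, a 1.4-fold higher number from compound 3 to compound 4 (0.15 log units; within the scatter), because a 1.7-fold lower number from compound 1 to compound 3 (0.23 log units; within the scatter) stayed within the scatter when the ring on the carbonyl carbon was last exchanged. Compound 4 is therefore estimated at 3500 nM, with a range from 1200 nM to 10000 nM.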

Compound 4, half-maximal inhibitory concentration: 5140 nM
Beside the measured number, compound 4's estimate is 1.5-fold (0.17 log units) below it; the measured number falls inside the stated range.
By their numbers in this assay, from the lowest: compounds 3, 1 and 4 (each within the scatter of the next, the first and the last beyond it); then compound 2.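

In this assay, pyrazin-2-yl and 1-methyl-1H-imidazol-2-yl match in their counts of heavy atoms, hydrogen-bond donors and hydrogen-bond acceptors, so the exchange alters mainly the ring size, and it gives a 2.1-fold higher number from compound 3 to compound 4 (0.31 log units; beyond the scatter) as the first measured move at this position from a six-membered to a five-membered aromatic ring. Ring size does not sort the compounds in a simple way, though: setting the same five-membered ring against pyridin-4-yl gives a 1.2-fold higher number from compound 1 to compound 4 (0.09 log units; within the scatter) and leaves those two compounds indistinguishable, although compound 3, also six-membered, lies beyond the scatter from compound 4. Against 2-hydroxypyridin-4-yl the five-membered ring gives a 2.3-fold lower number from compound 2 to compound 4 (0.36 log units; beyond the scatter) and so joins compound 1 and compound 3 in lying clearly apart from compound 2, which still shows the highest number of the four. No measurement shown offers a reason for any of these differences.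

The compounds shown leave open what the methyl group on the imidazole contributes, since 1H-imidazol-2-yl without it does not appear among them. They also leave open how other five-membered rings, such as thiazol-2-yl or furan-2-yl, or a saturated ring such as piperidine, would behave on this carbonyl carbon.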